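A few compounds are considered here, and "the series" means these few. Any claim that something is new, unique, unknown or untested is made for them only; others in the source may bear on it.

Compound 1 `COc1c(N2CC[C@@H](CO)C2)c(F)cc2c(=O)c(C(=O)O)cn(Cc3ccc(-c4ccccc4)cc3)c12` and compound 2 `CNCCNc1c(F)cc2c(=O)c(C(=O)O)cn(Cc3ccc(-c4ccccc4)cc3)c2c1OC` set the frame. In an assay on isolated protein for inhibition of DNA topoisomerase 1 (Homo sapiens), with a stated time of 15 min, tested at 200 uM (on this read-out lower numbers stand for less inhibition and higher numbers for more inhibition at the one concentration tested (going by the name of the read-out)), compound 1 gives 10%; in this assay compound 2 gives 10%. Among the compounds with values here, the one measured step, no change at the digits printed from compound 1 to compound 2 (within the scatter), shows a change at this position leaving the read-out flat, so compound 2 stands level with compound 1. Compound 3 `COc1c(N2CC[C@@H](C(N)=O)C2)c(F)cc2c(=O)c(C(=O)O)cn(Cc3ccc(-c4ccccc4)cc3)c12` carries 3-carbamoylpyrrolidin-1-yl in place of (2-(methylamino)ethyl)amino on an aromatic carbon. Within the data shown here, with the only comparable step flat, no movement beyond the scatter is expected in this assay; the expected step is no change at the digits printed from compound 2 to compound 3 (within the scatter). For compound 3 the estimate in this assay is 10%, in the range 0% to 25%.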

Compound 3, a percentage reported as inhibition, at one concentration (the size of the read-out at that concentration, not a potency): 10%
Compound 3: the middle estimate sits on the measured number at the digits printed, within the range that was stated.
By their numbers in this assay, from the lowest: compounds 1, 2 and 3 (each within the scatter of the next).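

In this assay, 3-carbamoylpyrrolidin-1-yl in place of (2-(methylamino)ethyl)amino on the aromatic carbon gives no change at the digits printed from compound 2 to compound 3 (within the scatter), so the flat read-out at this position now extends to a second ring substituent. Carbamoyl in place of hydroxymethyl on the saturated ring carbon adds a change further out on the substituent and gives no change at the digits printed from compound 1 to compound 3 (within the scatter), a comparison the earlier pair could not offer. No measured evidence bears on these level read-outs.

As far as these compounds go, whether an amine or a carboxylic acid in place of the carbamoyl would move the read-out remains open. The same holds for a longer chain on the aromatic carbon.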